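This account rests on a few compounds, and the source may have more. Where it says the series, first, only, none or still open, it means among the compounds named here.

Compound 1 `Cc1ccc(CS(=O)(=O)/C(=C/c2ccccc2OCc2ccccc2)C(=O)c2ccc(Cl)cc2)cc1` and compound 2 `COc1ccccc1/C=C(\C(=O)c1ccc(Cl)cc1)S(=O)(=O)Cc1ccc(C)cc1` share a core and differ only in one place. In a functional assay on DU-145 cells (Homo sapiens) for inhibition, read by trypan blue exclusion, with a stated time of 96 h (a higher number here means a weaker inhibitor of growth, a lower number a stronger inhibitor of growth), compound 1 gives 1000 nM, the lowest of the two numbers shown, while compound 2 gives 10000 nM, so the change of hydrogen in place of phenyl on a saturated chain carbon bound to an oxygen on an aromatic ring brought a 10-fold higher number from compound 1 to compound 2 (1.00 log units; beyond the scatter).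

Compound 3 `COc1ccc(S(=O)(=O)/C(=C/c2ccccc2OCc2ccccc2)C(=O)c2ccc(Cl)cc2)cc1` keeps the benzyl-bearing oxygen of compound 1 and alters the other end instead: 4-methoxyphenyl in place of 4-methylbenzyl on a sulfonyl sulfur. Among the compounds with values here, no measured step touches the group on the sulfonyl sulfur, so the only guide is that compound 1 gives 1000 nM and nothing shows how this position responds. The step from compound 1 to compound 3 is therefore expected to be small, a 1.5-fold higher number from compound 1 to compound 3 (0.18 log units; within the scatter), with wide uncertainty. Compound 3 is estimated to give 1500 nM in this assay, within a range from 300 nM to 8000 nM.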

Compound 3, concentration for 50% growth inhibition: 1000 nM
The estimate for compound 3 lay 1.5-fold (0.18 log units) above the measured number; the measured number falls inside the stated range.
By their numbers in this assay, from the lowest: compounds 1 and 3 (each within the scatter of the next); then compound 2.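

With no change at the digits printed from compound 1 to compound 3 (within the scatter) in this assay for 4-methoxyphenyl in place of 4-methylbenzyl on a sulfonyl sulfur, this position gains its first reading, and this change leaves growth inhibition unshifted. Both groups have 8 heavy atoms and one six-membered aromatic ring of carbon only, while the entering group brings 1 hydrogen-bond acceptor, so that difference in make-up goes with no shift beyond the scatter here. No measurement in hand explains why the two groups read alike.

As far as these compounds go, it remains open whether an amine, a carboxylic acid or a longer chain on the sulfonyl sulfur would also read alike. Also open, from the compounds shown here alone, is whether the loss seen with hydrogen in place of phenyl at the other end would hold with 4-methoxyphenyl on the sulfonyl sulfur.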